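Swapping a Fluoropyridyl Arm for a Trifluoromethylphenyl

The source may hold more compounds than are shown below. What is called first, only, known or untested is meant among the compounds shown, and "the series" means these compounds.

In an assay on HEK293 cells for activation of Kir3.1/Kir3.2 (Homo sapiens), read by thallium flux (on this read-out lower numbers stand for an effect already at smaller amounts and higher numbers for an effect only at larger amounts of compound), compound 1 `Cc1cc(NC(=O)Cn2nnc(-c3ccccn3)n2)n(C2CCCCC2)n1` gives 14600 nM. Compound 2 `Cc1cc(NC(=O)Cn2nnc(-c3ccc(F)cc3)n2)n(C2CCCCC2)n1` gives 180 nM in this assay, and an 81-fold lower number from compound 1 to compound 2 (1.91 log units; beyond the scatter) shows how large that gain is. Compound 3 `Cc1cc(NC(=O)Cn2nnc(-c3cccc(F)n3)n2)n(C2CCCCC2)n1` reaches only the limit of this assay, > 3000 nM, which is a limit and not a number (the limit of > 3000 nM in this assay, at which 1 of the 3 values shown sits). Reintroducing the ring nitrogen is seen in an at least 16-fold higher number from compound 2 to compound 3 (1.22 log units; beyond the scatter). Compound 4 `Cc1cc(NC(=O)Cn2nnc(-c3ccc(C(F)(F)F)cc3)n2)n(C2CCCCC2)n1` is not yet measured and differs from compound 3 by 4-(trifluoromethyl)phenyl in place of 6-fluoropyridin-2-yl on an aromatic carbon. Both measured steps, an 81-fold lower number from compound 1 to compound 2 (1.91 log units; beyond the scatter) and an at least 16-fold higher number from compound 2 to compound 3 (1.22 log units; beyond the scatter), move between a pyridin-2-yl type and a phenyl and are large, so the return to a phenyl is expected to give a large drop, an at least 8.5-fold lower number from compound 3 to compound 4 (0.93 log units; beyond the scatter). Compound 4 is therefore estimated at 350 nM, between 80 nM and 1500 nM.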

Compound 4, half-maximal effective concentration: 241 nM
Compound 4: the middle estimate sits 1.5-fold (0.16 log units) above what was measured; the measured number falls inside the stated range.
By their numbers in this assay, from the lowest: compounds 2 and 4 (each within the scatter of the next); then compound 1.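

On the aromatic carbon between two ring nitrogen atoms, the larger trifluoromethyl on the phenyl and the fluoro cannot be told apart, with a 1.3-fold higher number from compound 2 to compound 4 (0.13 log units; within the scatter). Both phenyl compounds stand well clear of the two pyridine compounds, with an at least 12-fold lower number from compound 3 to compound 4 (1.09 log units; beyond the scatter) and a 61-fold lower number from compound 1 to compound 4 (1.78 log units; beyond the scatter). The step from compound 3 rests on a limit and not a number: the limit of > 3000 nM in this assay, at which 1 of the 4 values shown sits.

The compounds shown leave open whether a phenyl bearing a nitrile, a methoxy group or an amine in place of trifluoromethyl would hold this level. They also leave open whether a pyridin-2-yl bearing trifluoromethyl would reach it.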